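A few compounds are considered here, and "the series" means these few. Any claim that something is new, unique, unknown or untested is made for them only; others in the source may bear on it.

The measured compounds are:

Compound 1, `Cc1cc(/C=C/c2ccc(O)cc2)[nH]n1`; in a functional assay on MCF7 cells (Homo sapiens) for cytotoxicity, read by MTT assay, with a stated time of 72 h (on this read-out higher numbers stand for weaker inhibition and lower numbers for stronger inhibition), compound 1 gives 48100 nM.
Compound 2, `COc1ccc(/C=C/c2cc(C)n[nH]2)cc1`; in this assay compound 2 gives 9700 nM.
Compound 3, `COc1ccc(/C=C/C(=O)CC(C)=O)cc1`; in this assay compound 3 gives 15800 nM.

Compound 2 and compound 1 share a core and differ only in one spot, (hydrogen in place of methyl on an oxygen on an aromatic ring), and that change produced a step of a 5.0-fold higher number from compound 2 to compound 1 (0.70 log units; beyond the scatter). Compound 4, `CC(=O)CC(=O)/C=C/c1ccc(O)cc1`, is not yet measured. It carries the core of compound 3, and its difference from compound 3 is hydrogen in place of methyl on an oxygen on an aromatic ring. The two "place" descriptions read the same word for word, so this is the same change made on another core; the difference between the two cores themselves is not broken down here, and the values of compound 3 and compound 2 lie within the scatter of each other.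

Among the compounds with values here, for compound 4 the expected step is a 4.4-fold higher number from compound 3 to compound 4 (0.65 log units; beyond the scatter) in this assay, set beside the measured step from compound 2 to compound 1 because that step, a 5.0-fold higher number from compound 2 to compound 1 (0.70 log units; beyond the scatter), is the only measured example of this change. The estimate for compound 4 in this assay is therefore 70000 nM, expected to fall between 25000 nM and 200000 nM.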

Compound 4, half-maximal inhibitory concentration: 19700 nM
Compound 4: the middle estimate sits 3.6-fold (0.55 log units) above what was measured; the measured number lies below the stated range.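

On the core of the diketone chain, swapping methoxy for hydroxy gave a 1.2-fold higher number from compound 3 to compound 4 (0.10 log units; within the scatter) in this assay, a step that cannot be told apart from no change at all. The same swap therefore did not carry its size from one core to the other in this series: the same change on two cores in this assay, a 5.0-fold higher number (0.70 log units; beyond the scatter) from compound 2 to compound 1 and a 1.2-fold higher number (0.10 log units; within the scatter) from compound 3 to compound 4, 4.0-fold (0.60 log units) apart, beyond the scatter of two such steps. This does not show why the two cores behave differently or which part of them matters, and two pairs give no rule for how the swap would behave on any further core.

The compounds shown carry only methyl or hydrogen on the oxygen on the aromatic ring, so it remains open how a longer chain on that oxygen, such as ethyl, would read in this assay. Also open, as far as these compounds go, is whether an amine or a carboxylic acid in place of the methoxy would follow the pattern of either core.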